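The source may hold more compounds than are shown below. What is called first, only, known or untested is meant among the compounds shown, and "the series" means these compounds.

Compound 2 `CC(C)(C)CNC(=O)c1ccc(C#Cc2cccc(F)c2)cn1` gives 63.9% in a functional assay on HEK293 cells for positive allosteric modulation of metabotropic glutamate receptor 5 (Rattus norvegicus), read by fluorescence and calcium flux (a higher number here means a larger maximal response, a lower number a smaller maximal response), and compound 1 `CC(C)CNC(=O)c1ccc(C#Cc2cccc(F)c2)cn1` gives 58.2%, so the two stand within the scatter of each other, the step of a number 5.7 percentage points higher from compound 1 to compound 2 (within the scatter) being small. Compound 3 `O=C(NCC1CC1)c1ccc(C#Cc2cccc(F)c2)cn1` differs from compound 2 by cyclopropyl in place of tert-butyl on a saturated chain carbon bound to an amide-type nitrogen. Among the compounds with values here, the only measured step, a number 5.7 percentage points higher from compound 1 to compound 2 (within the scatter), also alters the saturated chain carried by the amide and stayed within the scatter, so for compound 3 a step of a number 5.9 percentage points lower from compound 2 to compound 3 (within the scatter) is expected in this assay, with no change beyond the scatter. Compound 3 is therefore estimated at 58%, in a range from 45% to 72%.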

Compound 3, largest response reached (reported as efficacy), in percent of the reference or control that the assay uses: 61.4%
The estimate for compound 3 lay 3.4 percentage points below the measured number; the range from low to high includes it.
By their numbers in this assay, from the lowest: compounds 1, 3 and 2 (each within the scatter of the next).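

Exchanging tert-butyl for cyclopropyl on a saturated chain carbon bound to an amide-type nitrogen gives a number 2.5 percentage points lower from compound 2 to compound 3 (within the scatter), and exchanging isopropyl for cyclopropyl gives a number 3.2 percentage points higher from compound 1 to compound 3 (within the scatter). In this assay, the maximal response thus stays within the scatter when a three-membered ring takes the place of either open branched group, which the two earlier compounds could not show. Nothing measured here accounts for this result.

On these data alone, whether an amine, a carboxylic acid or a longer chain at this place would also stay within the scatter remains open. So does the outcome for a cyclohexyl ring.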